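A few compounds are considered here, and "the series" means these few. Any claim that something is new, unique, unknown or untested is made for them only; others in the source may bear on it.

Of the compounds shown here, three sharing one core have been read in a physicochemical assay for solubility, in phosphate buffer, measured as kinetic solubility, at pH 7.4, tested at 250 uM; on this read-out lower numbers stand for lower solubility and higher numbers for higher solubility. Compound 1 `CCCCCCCCNc1ccc(C(=O)O)cc1S(N)(=O)=O` gives > 250000 nM, which is a limit of the assay and not a number. Compound 2 `CCCCCCCCNc1ccc(C(=O)O)cc1S(=O)(=O)NC` gives 53000 nM, and compound 3 `CN(C)S(=O)(=O)c1cc(C(=O)O)ccc1NCCCC(F)(F)F` gives 245000 nM, the higher of these two actual numbers.

Compound 4 `COCCCCCCNc1ccc(C(=O)O)cc1S(=O)(=O)N(C)C` differs from compound 3 only at the end of its chain, where 3-methoxypropyl stands in place of trifluoromethyl on a saturated chain carbon, three bonds along the chain from a nitrogen on an aromatic ring (3-methoxypropyl in place of trifluoromethyl on a saturated chain carbon, three bonds along the chain from a nitrogen on an aromatic ring). Read one bond further out, this is 4,4,4-trifluorobutyl to 6-methoxyhexyl.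

Going by the values given here, no step at the chain end has been measured. Among the compounds with values here, the only measured step, an at least 4.7-fold lower number from compound 1 to compound 2 (0.67 log units; beyond the scatter), is methyl in place of hydrogen on a sulfonamide nitrogen, so it bears only loosely, though it shows that one small change can shift this assay beyond the scatter. Compound 3 at 245000 nM leaves more room downward than upward. The expected change is a modest fall, a 2.2-fold lower number from compound 3 to compound 4 (0.35 log units; beyond the scatter). For compound 4 the estimate is 110000 nM, with an expected range of 40000 nM to 250000 nM.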

Compound 4, solubility: > 250000 nM
Compound 4: no number, only a limit; the forecaster's own chance of this, stated with the estimate: 20%; middle value at least 2.2-fold (0.35 log units) away from the limit.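

In this assay the swap of trifluoromethyl for 3-methoxypropyl gives an at least 1.0-fold higher number from compound 3 to compound 4 (0.00 log units; that floor lies within the scatter) at the chain end, the first step read at this position. Compound 4 gives > 250000 nM as its reading, which is a limit of the assay and not a number. The longer chain with its methoxy end therefore brings no measured fall here, and the step has only a floor because compound 4 stands at a limit: the limit of > 250000 nM in this assay, at which 2 of the 4 values shown sit.

Going by these compounds, how far the reading of compound 4 would lie past that limit stays open, so the size of the step cannot be told. The change also alters chain length and chain end together, so a plain hexyl chain, or an amine at the chain end, would be needed to tell those two apart.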